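Dropping the fluoro group from compound 3

The source may hold more compounds than are shown below. What is called first, only, known or untested is meant among the compounds shown, and "the series" means these compounds.

In a functional assay on A549 cells (Homo sapiens) for cytotoxicity, read by WST assay, with a stated time of 48 h (on this read-out higher numbers stand for weaker inhibition and lower numbers for stronger inhibition), compound 1 `N#C/C(=C\c1c[nH]c2ccccc12)C(=O)c1c[nH]c2ccccc12` gives 22000 nM. Compound 2 `N#C/C(=C\c1cn(Cc2ccc(Cl)cc2)c2ccccc12)C(=O)c1c[nH]c2ccccc12` reaches only a limit of the assay, > 50000 nM. Among the measured compounds shown here, compound 3 `COc1ccc(Cn2cc(/C=C(\C#N)C(=O)c3c[nH]c4cc(F)ccc34)c3ccccc32)cc1` gives 36300 nM, which lies within the scatter of the value of compound 1, the only other compound here with a true number.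

Compound 4 `COc1ccc(Cn2cc(/C=C(\C#N)C(=O)c3c[nH]c4ccccc34)c3ccccc32)cc1` differs from compound 3 by hydrogen in place of fluoro on an aromatic carbon. In words, this is hydrogen in place of fluoro on an aromatic carbon, so that 6-fluoro-1H-indol-3-yl becomes 1H-indol-3-yl. For the measured compounds named here, the only measured step, an at least 2.2-fold higher number from compound 1 to compound 2 (0.35 log units; beyond the scatter), is a different change, 4-chlorobenzyl in place of hydrogen on an aromatic nitrogen, and it sets no size for this one. Going by the values given here, no measured pair covers the loss of the fluoro group. No shift beyond the scatter is therefore expected in this assay, in either direction. The expected move is a 1.0-fold higher number from compound 3 to compound 4 (0.02 log units; within the scatter). For compound 4 the estimated value is 38000 nM, with an expected range of 20000 nM to 50000 nM.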

Compound 4, half-maximal inhibitory concentration: > 50000 nM
Compound 4 ended at the assay's limit; the forecaster's own chance of this, stated with the estimate: 25%; at least 1.3-fold (0.11 log units) between middle value and limit.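

Compound 4 stands at a limit of the assay in this assay, so it gives no true number. The loss of the fluoro group amounts to an at least 1.3-fold higher number from compound 3 to compound 4 (0.13 log units; that floor lies within the scatter), which neither shows nor rules out a shift beyond the scatter at this position, while the 4-methoxybenzyl group on the aromatic nitrogen gives an at least 2.2-fold higher number from compound 1 to compound 4 (0.35 log units; beyond the scatter), the same direction as an at least 2.2-fold higher number from compound 1 to compound 2 (0.35 log units; beyond the scatter). The change of chloro to methoxy on the benzyl group cannot be read, because compound 2 and compound 4 both rest on the same limit: the limit of > 50000 nM in this assay, at which 2 of the 4 values shown sit.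

Going by these compounds, the true size of the fluoro step remains open, as does whether that step would look the same in compound 1, which carries no benzyl group. Also open, on these data alone, is how an amine or a carboxylic acid in place of the fluoro group would read in this assay.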